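The source may report more compounds than this note shows. Statements on the series, on what has been measured and on what is new or still open speak of the compounds shown alone.

Three compounds have been measured so far:
compound 1, `CN1CCN(c2nc(NCc3ccc(NC(=O)c4ccc(F)cc4)cc3)c3ccccc3n2)CC1`, 2500 nM;
compound 2, `CNc1nc(NCc2ccc(NS(=O)(=O)c3ccc(F)cc3)cc2)c2ccccc2n1`, 4800 nM;
compound 3, `Cc1ccc(S(=O)(=O)Nc2ccc(CNc3nc(N(C)C)nc4ccccc34)cc2)cc1`, 13000 nM.

All three numbers come from a functional assay on SW480 cells (Homo sapiens) for inhibition, read by luminescence and resazurin assay, with a stated time of 3 days; a lower number here means a stronger inhibitor, a higher number a weaker inhibitor. Compound 2 stands second highest of the three numbers. Its nearest neighbour is compound 1, whose number lies within the usual scatter of that of compound 2, so the two cannot be ranked against each other. Compound 3 is furthest from compound 2, with a number beyond the scatter higher, so compound 3 is the weaker inhibitor of that pair.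

The account now follows the step from compound 2 to compound 4, `CNc1nc(NCc2ccc(NC(=O)c3ccc(F)cc3)cc2)c2ccccc2n1`, which has not yet been measured in this assay. The change is: (4-fluorophenyl)carbonyl in place of (4-fluorophenyl)sulfonyl on a nitrogen on an aromatic ring.

Among the measured compounds shown here, no two measured compounds differ in only one place, so no measured step sets the size of this one. Compound 1 also carries the (4-fluorophenyl)carbonyl group, but it differs from compound 2 in more than one place, so it only hints at the direction. In this assay a small step toward stronger inhibition, probably within the scatter, is expected for compound 4. The estimate for compound 4 is 3000 nM, with a range from 1200 nM to 8000 nM. The step this estimate means, a 1.6-fold lower number from compound 2 to compound 4 (0.20 log units; within the scatter), is expected to be modest.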

Compound 4, half-maximal inhibitory concentration: 2000 nM
For compound 4 the middle estimate is 1.5-fold (0.18 log units) above the measured one, within the range that was stated.
By their numbers in this assay, from the lowest: compounds 4, 1 and 2 (each within the scatter of the next, the first and the last beyond it); then compound 3.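

In this assay, (4-fluorophenyl)carbonyl in place of (4-fluorophenyl)sulfonyl on a nitrogen on an aromatic ring gives a 2.4-fold lower number from compound 2 to compound 4 (0.38 log units; beyond the scatter) and so provides the first single change measured at this place, with a step that the assay can resolve. With the (4-fluorophenyl)carbonyl group held constant, methylamino in place of 4-methylpiperazin-1-yl on an aromatic carbon gives a 1.3-fold lower number from compound 1 to compound 4 (0.10 log units; within the scatter) and so does not separate these two groups. Nothing measured here accounts for either step. The compounds shown leave open how a urea or a sulfamide would compare with the carbonyl and sulfonyl links on that nitrogen. They also leave open whether a morpholine or a primary amine on that aromatic carbon would stay as close to methylamino as 4-methylpiperazin-1-yl does.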